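The source may hold more compounds than are shown below. What is called first, only, known or untested is meant among the compounds shown, and "the series" means these compounds.

Compound 1 `CCCC[C@H](C)[C@H](OC(N)=O)[C@@H](C)[C@H](O)[C@@H](C)C/C(C)=C\[C@H](C)[C@@H](O)[C@@H](C)CCCC[C@@H]1OC(=O)[C@H](C)[C@@H](O)[C@H]1C` is a macrolactone whose long side chain carries a carbamate and several hydroxy groups. In a functional assay on A549 cells (Homo sapiens) for cytotoxicity (on this read-out lower numbers stand for stronger inhibition and higher numbers for weaker inhibition), compound 1 gives 377 nM. Compound 2 `C=C/C=C\[C@H](C)[C@H](O)[C@@H](C)[C@H](O)[C@@H](C)C/C(C)=C\[C@H](C)[C@H]1OC(=O)C=C[C@@H]1C` is a shorter relative with a different lactone. In this assay compound 2 shows > 12700 nM, which is a limit of the assay rather than a measured number. Among the two values shown, compound 1 therefore stands as the only one with an actual number; the other sits at the limit (the limit of > 12700 nM in this assay, at which 1 of the 2 values shown sits).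

Compound 3 `CCCC[C@H](C)[C@H](OC(N)=O)[C@@H](C)[C@H](O)[C@@H](C)C/C(C)=C\[C@H](C)[C@@H](O)[C@@H](C)CC[C@@H](O)C[C@@H]1OC(=O)[C@H](C)[C@@H](O)[C@H]1C` differs from compound 1 by hydroxy in place of hydrogen on a saturated chain carbon bound to two saturated chain carbons. For the measured compounds named here, no step between two measured compounds is available to compare this change with. A hydroxy on a saturated chain carbon bound to two saturated chain carbons is expected to shift potency in this assay only modestly, if at all, with the expected step from compound 1 to compound 3 being a 1.3-fold higher number from compound 1 to compound 3 (0.12 log units; within the scatter). The estimate for compound 3 in this assay is 500 nM, with a range from 150 nM to 2000 nM.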

Compound 3, half-maximal inhibitory concentration: 67.7 nM
Beside the measured number, compound 3's estimate is 7.4-fold (0.87 log units) above it, outside the stated range (below it).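

In this assay, placing a hydroxy in place of hydrogen on a saturated chain carbon bound to two saturated chain carbons gives a 5.6-fold lower number from compound 1 to compound 3 (0.75 log units; beyond the scatter). For the compounds shown here, this is the first step between two measured compounds here, and it shows that this place on the chain responds to a single added hydroxy, with stronger inhibition by more than the usual scatter. No measurement shown gives a reason for this gain.

As far as these compounds go, whether a methoxy, an amine or a fluorine at the same place would give a similar gain remains open. A single step also cannot tell whether a hydroxy on other carbons of the chain, or on a different core, would act the same way.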